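The compounds below may be only part of what the source reports. "The series", "measured", "known", "first", "only" and "open" are said of these compounds alone.

Measured in a functional assay on HCT-116 cells (Homo sapiens) for cytotoxicity, read by MTT assay, with a stated time of 72 h; on this read-out higher numbers stand for weaker inhibition and lower numbers for stronger inhibition:
Compound 1 `Oc1ccc(C2C/C(=N\NC(=S)N3CCOCC3)c3ccc(O)cc3O2)cc1`: 63500 nM
Compound 2 `CC(C)(C)NC(=S)N/N=C1\CC(c2ccc(O)cc2)Oc2cc(O)ccc21`: 25900 nM

Of the two, compound 1 stands higher, at 63500 nM, and its nearest neighbour is compound 2, at 25900 nM. Compound 3 `CCCN(CCC)C(=S)N/N=C1\CC(c2ccc(O)cc2)Oc2cc(O)ccc21` has not yet been measured in this assay. It differs from compound 1 in one place, with dipropylamino in place of morpholin-4-yl on a thiocarbonyl carbon.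

Among the measured compounds shown here, only one measured step bears on this change: a 2.5-fold lower number from compound 1 to compound 2 (0.39 log units; beyond the scatter). That modest step, beyond the scatter, has (tert-butyl)amino in place of morpholin-4-yl on the same thiocarbonyl carbon. For the measured compounds named here, no measured compound carries dipropylamino, and a single step establishes no trend. A step of similar modest size towards a lower number is therefore expected, with wide uncertainty. The expected step is a 2.5-fold lower number from compound 1 to compound 3 (0.40 log units; beyond the scatter). For compound 3 the estimated value is 25000 nM, with an expected range of 9000 nM to 60000 nM.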

Compound 3, half-maximal inhibitory concentration: 41900 nM
Compound 3: the middle estimate sits 1.7-fold (0.22 log units) below what was measured; the range from low to high includes it.
By their numbers in this assay, from the lowest: compounds 2, 3 and 1 (each within the scatter of the next, the first and the last beyond it).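

In this assay, putting dipropylamino in place of morpholin-4-yl on the thiocarbonyl carbon gives a 1.5-fold lower number from compound 1 to compound 3 (0.18 log units; within the scatter) and so, unlike the (tert-butyl)amino change, does not separate compound 3 from compound 1 on this read-out. Compound 3 also cannot be told apart from compound 2, since the exchange of (tert-butyl)amino for dipropylamino gives a 1.6-fold higher number from compound 2 to compound 3 (0.21 log units; within the scatter) and leaves these two ring-free groups undistinguished at this place. Of the three steps now available, only a 2.5-fold lower number from compound 1 to compound 2 (0.39 log units; beyond the scatter) lies beyond the scatter, so the morpholin-4-yl group has a clear difference from only one of its two replacements, and nothing measured here accounts for any of these steps.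

Going by these compounds, it remains open whether a smaller dimethylamino group, a piperidin-1-yl ring without the oxygen, or a chain ending in a carboxylic acid or a primary amine on this carbon would move the number further than these three groups do. On these data alone, it is also open whether a change elsewhere on the shared core, such as replacing either hydroxyl group with methoxy, would matter more than any change at this thiocarbonyl carbon.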